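Cyclopropyl in place of pyridin-2-yl: what to expect

The source may hold more compounds than are shown below. What is called first, only, known or untested is meant among the compounds shown, and "the series" means these compounds.

In a physicochemical assay for permeability, using PAMPA (a higher number here means that the compound crosses the layer faster, a lower number that the compound crosses the layer more slowly), three compounds sharing one core differ by a single group on an aromatic carbon. Compound 2 (`O=C(O)CCn1c(=O)oc2cc(Cl)c(Cl)cc21`), with chloro, gives 24 nm/s as its number. Compound 3 (`O=C(O)CCn1c(=O)oc2cc(OCc3ccccn3)c(Cl)cc21`), with (pyridin-2-yl)methoxy, gives 11 nm/s and so stands lower than compound 2. Compound 1 (`CCc1cc2oc(=O)n(CCC(=O)O)c2cc1Cl`), with ethyl, gives only a limit of < 10 nm/s and no number.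

Compound 4 (`O=C(O)CCn1c(=O)oc2cc(OCC3CC3)c(Cl)cc21`) differs from compound 3 in one place (cyclopropyl in place of pyridin-2-yl on a saturated chain carbon bound to an oxygen on an aromatic ring) and so carries cyclopropylmethoxy instead of (pyridin-2-yl)methoxy. Going by the values given here, no measured step changes this group directly. The closest guide is the swap from chloro to (pyridin-2-yl)methoxy, which gave a 2.2-fold lower number from compound 2 to compound 3 (0.34 log units; beyond the scatter) and was modest. The swap from ethyl gave an at least 1.1-fold higher number from compound 1 to compound 3 (0.04 log units; that floor lies within the scatter) and rests on a limit. Compound 4 loses the pyridin-2-yl of compound 3, so a modest rise in this assay is expected, about as large as that drop. The estimated change is a 2.3-fold higher number from compound 3 to compound 4 (0.36 log units; beyond the scatter) in this series. For compound 4 the expected value is 25 nm/s within a range of 11 nm/s to 60 nm/s overall.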

Compound 4, apparent permeability: 19 nm/s
Beside the measured number, compound 4's estimate is 1.3-fold (0.12 log units) above it, within the range that was stated.
By their numbers in this assay, from the lowest: compounds 3, 4 and 2 (each within the scatter of the next, the first and the last beyond it). At a limit, below all of these: compound 1.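

In this assay, the step of a 1.7-fold higher number from compound 3 to compound 4 (0.24 log units; within the scatter) shows that trading pyridin-2-yl for cyclopropyl at this saturated chain carbon does not move the number past the scatter. Cyclopropylmethoxy also stays within the scatter of chloro, at a 1.3-fold lower number from compound 2 to compound 4 (0.10 log units; within the scatter), whereas (pyridin-2-yl)methoxy stood apart from chloro at a 2.2-fold lower number from compound 2 to compound 3 (0.34 log units; beyond the scatter), so a group this size on the aromatic carbon does not by itself separate a compound from compound 2. Compound 1 has a limit and not a number, so the step of an at least 1.9-fold higher number from compound 1 to compound 4 (0.27 log units; that floor lies within the scatter) offers only a floor: the limit of < 10 nm/s in this assay, at which 1 of the 4 values shown sits.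

Compound 4 swaps the ring and removes its nitrogen in one change, and the compounds shown leave open which of the two matters. Phenyl in place of pyridin-2-yl would keep the six-membered aromatic ring without that nitrogen, and an amine on the same chain remains unexplored here.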